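A few compounds are considered here, and "the series" means these few. Any claim that something is new, unique, unknown or untested is made for them only; others in the source may bear on it.

Of the compounds shown here, three have been measured in a functional assay on Daoy cells (Homo sapiens) for cytotoxicity, read by MTT assay, with a stated time of 72 h; a lower number here means a stronger inhibitor, a higher number a weaker inhibitor. Compound 1 `COc1cc(NC(=O)Nc2cccc(F)c2)cc(OC)c1OC` gives 111000 nM. Compound 2 `COc1cc(NC(=O)Nc2cccc([N+](=O)[O-])c2)cc(OC)c1OC` gives 82500 nM. Compound 3 `COc1cc(NC(=O)c2ccc([N+](=O)[O-])cc2)cc(OC)c1OC` gives 52900 nM. All three carry the same trimethoxyphenyl part on one side of the molecule, and they differ on the other side.

Compound 2 and compound 1 differ in one place only: fluoro in place of nitro on an aromatic carbon. In this assay this change made a step of a 1.3-fold higher number from compound 2 to compound 1 (0.13 log units; within the scatter). Compound 3 differs from compound 2 in more than one place, and the difference between the two cores is not broken down here. The number of compound 3 and that of compound 2 lie within the usual scatter of each other, while the gap between compound 3 and compound 1 lies beyond it.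

Compound 4 `COc1cc(NC(=O)c2ccc(F)cc2)cc(OC)c1OC` has not yet been measured. Within the data shown here, it differs from compound 3 by fluoro in place of nitro on an aromatic carbon, the same kind of change as the one from compound 2 to compound 1, though not on the same place: in the earlier pair the group stands meta to a large group, here it stands para to a large group. Since the earlier step was small, a step of about a 1.3-fold higher number from compound 3 to compound 4 (0.12 log units; within the scatter) is expected from compound 3 to compound 4, because a 1.3-fold higher number from compound 2 to compound 1 (0.13 log units; within the scatter) changed the number by little. Compound 4 is therefore estimated at 70000 nM, with a likely range from 30000 nM to 160000 nM.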

Compound 4, half-maximal inhibitory concentration: >= 125000 nM
Compound 4 gave a limit, no number; the forecaster's own chance of this, stated with the estimate: 15%; middle value at least 1.7-fold (0.25 log units) away from the limit.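

In this assay compound 4 gives >= 125000 nM, which is a limit of the assay and not a number. On the core of compound 3, fluoro in place of nitro gave an at least 2.3-fold higher number from compound 3 to compound 4 (0.37 log units; beyond the scatter), so here the change leads to a weaker inhibitor by more than the usual scatter, while the same kind of change on the core of compound 1 gave a 1.3-fold higher number from compound 2 to compound 1 (0.13 log units; within the scatter). This shows that the change did not give a step beyond the scatter on both cores, but it does not show that the core alters the size of the step, and one pair on each core is too little to make a rule for the series: the same change on two cores in this assay, a 1.3-fold higher number (0.13 log units; within the scatter) from compound 2 to compound 1 and an at least 2.3-fold higher number (0.37 log units; beyond the scatter) from compound 3 to compound 4; the limit leaves it open whether they differ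

On these data alone, how far the number of compound 4 lies past the limit stays open, and with it the true size of its step. The compounds shown also carry only nitro or fluoro at the changed place, which leaves open how a chlorine atom, a methoxy group, an amine or a carboxylic acid there would read on either core.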